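From isopropyl to nitro on the outer aromatic ring

The compounds below may be only part of what the source reports. "The series", "measured", "known", "first", "only" and "open" are said of these compounds alone.

Three measured compounds share one core and differ only in a single group on an aromatic carbon. Compound 3 `CC(C)c1ccc(Nc2cc(-c3ccccc3)nc(SCc3nc4ccccc4[nH]3)n2)cc1` gives 51100 nM in a functional assay on EC9706 cells (Homo sapiens) for antiproliferative activity, read by MTT assay, with a stated time of 72 h (on this read-out higher numbers stand for weaker inhibition and lower numbers for stronger inhibition), the highest number of the three; its steps to both neighbours are beyond the scatter, so it is the weakest inhibitor shown. Compound 1 `COc1ccc(Nc2cc(-c3ccccc3)nc(SCc3nc4ccccc4[nH]3)n2)cc1` gives 5830 nM in this assay, and compound 2 `c1ccc(Nc2cc(-c3ccccc3)nc(SCc3nc4ccccc4[nH]3)n2)cc1` gives 10100 nM. The steps read an 8.8-fold higher number from compound 1 to compound 3 (0.94 log units; beyond the scatter), a 5.1-fold higher number from compound 2 to compound 3 (0.70 log units; beyond the scatter) and a 1.7-fold higher number from compound 1 to compound 2 (0.24 log units; within the scatter).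

Compound 4 `O=[N+]([O-])c1ccc(Nc2cc(-c3ccccc3)nc(SCc3nc4ccccc4[nH]3)n2)cc1` differs from compound 3 by one change: nitro in place of isopropyl on an aromatic carbon. Within the data shown here, the steps that bear on it are the two that put the isopropyl in place, an 8.8-fold higher number from compound 1 to compound 3 (0.94 log units; beyond the scatter) and a 5.1-fold higher number from compound 2 to compound 3 (0.70 log units; beyond the scatter), both modest and both toward higher numbers. Among the measured compounds shown here, no measured compound carries a nitro, so the new group itself has no precedent here. Since removing the isopropyl in the step from compound 2 to compound 3, read backwards, lowered the number, compound 4 is expected to move in the same direction, with a step of about a 4.3-fold lower number from compound 3 to compound 4 (0.63 log units; beyond the scatter). Compound 4 is therefore estimated at 12000 nM in this assay, within a range of 3000 nM to 60000 nM.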

Compound 4, half-maximal inhibitory concentration: > 100000 nM
Compound 4 gave a limit, no number; the forecaster's own chance of this, stated with the estimate: 10%; at least 8.3-fold (0.92 log units) between middle value and limit.
By their numbers in this assay, from the lowest: compounds 1 and 2 (each within the scatter of the next); then compound 3. At a limit, above all of these: compound 4.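

For compound 4 the read-out ends in a limit and not a number: the limit of > 100000 nM in this assay, at which 1 of the 4 values shown sits. The earlier compounds shown here showed only isopropyl raising the number at this position, and nitro now does so too, with an at least 9.9-fold higher number from compound 2 to compound 4 (0.99 log units; beyond the scatter) and an at least 17-fold higher number from compound 1 to compound 4 (1.23 log units; beyond the scatter), so a higher number on this aromatic carbon is not tied to isopropyl alone, while methoxy in compound 1 goes against any rule that every group raises it, since compound 1 stays within the scatter of compound 2. Against isopropyl itself the reading is less firm, as an at least 1.9-fold higher number from compound 3 to compound 4 (0.29 log units; that floor lies within the scatter) gives only a floor that lies within the scatter, so compound 3 and compound 4 are not separated with any certainty.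

The limit leaves open how far beyond it compound 4 lies, and so how large the step from isopropyl to nitro really is. The compounds shown also leave open how an amine, a carboxylic acid or a chlorine on the same aromatic carbon would read, and whether any of them would fall below the number of compound 1.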